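Sulfonyl Substituent Swap in a Growth Hormone Secretagogue Series

The source may report more compounds than this note shows. Statements on the series, on what has been measured and on what is new or still open speak of the compounds shown alone.

The three measured compounds share one core and differ in the group on the sulfonyl sulfur. In a functional assay for agonist activity at growth hormone secretagogue receptor type 1 (Homo sapiens), read by FLIPR (on this read-out lower numbers stand for an effect already at smaller amounts and higher numbers for an effect only at larger amounts of compound), compound 1 `COc1cc2c(cc1N1C[C@@H](C)N(C)[C@@H](C)C1)N(S(=O)(=O)c1cccc(Br)c1)CC2` gives 126 nM. Compound 2 `COc1cc2c(cc1N1C[C@@H](C)N[C@@H](C)C1)N(S(=O)(=O)Cc1cccc(I)c1)CC2` gives 31.6 nM in this assay, and compound 3 `COc1cc2c(cc1N1C[C@@H](C)N[C@@H](C)C1)N(S(=O)(=O)c1cccc(-c3ccccn3)c1)CC2` gives 20 nM. Among these three numbers compound 2 stands second highest: its value and that of compound 3 lie within the scatter of each other, whereas compound 1 sits beyond the scatter with the higher number. Compound 4 `COc1cc2c(cc1N1C[C@@H](C)N[C@@H](C)C1)N(S(=O)(=O)c1ccc(-c3ccon3)s1)CC2` remains to be measured and differs from compound 2 by 5-(1,2-oxazol-3-yl)thiophen-2-yl in place of 3-iodobenzyl on a sulfonyl sulfur. Among the compounds with values here, no comparable step has been measured, so the expected change is a 1.1-fold lower number from compound 2 to compound 4 (0.02 log units; within the scatter), meaning no shift beyond the scatter. Compound 4 is therefore expected to give 30 nM in this assay, within a range of 10 nM to 90 nM.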

Compound 4, half-maximal effective concentration: 2.51 nM
Compound 4: middle estimate off by 12-fold (1.08 log units), on the high side; the whole stated range lies above it.
By their numbers in this assay, from the lowest: compound 4; then compounds 3 and 2 (each within the scatter of the next); then compound 1.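

The group on the sulfonyl sulfur can move the number in this assay by a large margin: 5-(1,2-oxazol-3-yl)thiophen-2-yl in place of 3-iodobenzyl gives a 13-fold lower number from compound 2 to compound 4 (1.10 log units; beyond the scatter). Within the data shown here, this is the first single-place step, and the change brings in two five-membered aromatic rings and hydrogen-bond acceptors. No measurement at hand explains the step.

Which of the two rings accounts for the step remains open. Also open, from the compounds shown here alone, is whether an amine or a carboxylic acid in place of the 1,2-oxazol-3-yl group would keep it.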